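This account rests on a few compounds, and the source may have more. Where it says the series, first, only, none or still open, it means among the compounds named here.

Measured in a functional assay on A549 cells (Homo sapiens) for antiproliferative activity, read by MTT assay, with a stated time of 24 h; on this read-out higher numbers stand for weaker inhibition and lower numbers for stronger inhibition:
- compound 1 `O=S(=O)(c1ccc(Br)cc1)n1c(-c2cn(-c3ccccc3)nc2-c2ccc(F)cc2)nc2ccccc21`: 1720 nM
- compound 2 `O=[N+]([O-])c1ccc(S(=O)(=O)n2c(-c3cn(-c4ccccc4)nc3-c3ccc(C(F)(F)F)cc3)nc3ccccc32)cc1`: 790 nM

Compound 2 holds the lower number of the two, and its gap to compound 1 lies beyond the scatter. Compound 3 `O=S(=O)(c1ccc(Br)cc1)n1c(-c2cn(-c3ccccc3)nc2-c2ccc(C(F)(F)F)cc2)nc2ccccc21` carries bromo in place of nitro on an aromatic carbon of compound 2, para to a large group: bromo in place of nitro on an aromatic carbon. Going by the values given here, no measured step isolates this change, so only a modest rise in this assay is expected, possibly none beyond the scatter. Among the compounds with values here, the one bromo reference is compound 1 at 1720 nM, which also differs elsewhere. The expected step is a 1.4-fold higher number from compound 2 to compound 3 (0.14 log units; within the scatter). Compound 3 is estimated at 1100 nM, with an expected range of 450 nM to 2700 nM.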

Compound 3, half-maximal inhibitory concentration: 1690 nM
Compound 3: middle estimate off by 1.5-fold (0.19 log units), on the low side, within the range that was stated.
By their numbers in this assay, from the lowest: compound 2; then compounds 3 and 1 (each within the scatter of the next).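

In this assay, the change from 4-nitrophenyl to 4-bromophenyl on the sulfonyl gives a 2.1-fold higher number from compound 2 to compound 3 (0.33 log units; beyond the scatter), so nitro at this place, para to a large group, holds the lower number. With bromo held, trifluoromethyl in place of fluoro gives a 1.0-fold lower number from compound 1 to compound 3 (0.01 log units; within the scatter), with no change to read at that other aromatic carbon. Nothing available accounts for either step.

Going by these compounds, whether the nitro-to-bromo step holds with fluoro in place of trifluoromethyl stays open. So does how an amine, a methoxy group or a nitrile would read at this place.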